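Hydroxymethylphenyl to fluoromethylphenyl: a lipophilicity projection

The compounds below may be only part of what the source reports. "The series", "measured", "known", "first", "only" and "open" are said of these compounds alone.

Two compounds of this series have been characterized in a physicochemical assay for lipophilicity, read by HPLC, at pH 7.5; a lower number here means a more polar compound, a higher number a more lipophilic compound. Compound 1 `CC[C@@H](Nc1c(C#N)c(-c2ccc(-c3ccccc3NC)cc2)nc2cnccc12)C(N)=O` gives 2.5 in this assay. Going by the values given here, compound 2 `CC[C@@H](Nc1c(C#N)c(-c2ccc(-c3cccc(CO)c3)cc2)nc2cnccc12)C(N)=O` gives 2 in this assay and thus stands lowest of the two numbers; the only measured step leading to it is a number 0.50 log units lower from compound 1 to compound 2 (beyond the scatter), where the 3-(hydroxymethyl)phenyl group brought the number down.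

Compound 3 `CC[C@@H](Nc1c(C#N)c(-c2ccc(-c3cccc(C)c3F)cc2)nc2cnccc12)C(N)=O` is the next compound to be read in this assay. It differs from compound 2 as follows: 2-fluoro-3-methylphenyl in place of 3-(hydroxymethyl)phenyl on an aromatic carbon

The measured step from compound 1 to compound 2 bears on this change only partly, since it shows what the 3-(hydroxymethyl)phenyl group does relative to a 2-(methylamino)phenyl group carrying a donor of its own. Here the leaving group takes one hydrogen-bond donor and one hydrogen-bond acceptor with it and the entering 2-fluoro-3-methylphenyl group brings none. On that basis compound 3 is expected to move upward by a number 1.10 log units higher from compound 2 to compound 3 (beyond the scatter), beyond the scatter. Compound 3 is therefore estimated at 3.1, within a range from 2.6 to 3.6 in this assay.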

Compound 3, distribution coefficient: 3
Estimate against measurement, compound 3: 0.10 log units above; low and high end bracket the measured number.
By their numbers in this assay, from the lowest: compound 2; then compound 1; then compound 3.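

In this assay, going by these compounds alone, the 2-fluoro-3-methylphenyl group gives the highest number of the series so far: the reading is a number 1.00 log units higher from compound 2 to compound 3 (beyond the scatter), and it is also a number 0.50 log units higher from compound 1 to compound 3 (beyond the scatter). The position para to a large group therefore now spans three separate readings, each beyond the scatter of the others, and the widest step runs between two groups of 8 heavy atoms each, so it comes with no change in that count. No measurement shown here explains why the number moves as it does.

The step from compound 2 to compound 3 changes several things at once, removing the hydroxymethyl group while adding a fluorine and a methyl group, so the share of each in the rise cannot be separated. Single-change neighbours such as a 3-methylphenyl, a 2-fluorophenyl or a 3-(methoxymethyl)phenyl group would be needed to divide it, and whether a charged group such as a 3-(aminomethyl)phenyl or a 3-carboxyphenyl group would extend the range downward remains open.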